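Swapping a thiophene for a pyridine on the core

The source may report more compounds than this note shows. Statements on the series, on what has been measured and on what is new or still open speak of the compounds shown alone.

Measured so far:
Compound 1, `CCOC(=O)c1cnc(CC)nc1NN1C(=O)C=C(C)C1=O`: 10000 nM
Compound 2, `CCOC(=O)c1cnc(-c2cccs2)nc1NN1C(=O)C=C(C)C1=O`: 20 nM

In a functional assay on Jurkat cells for inhibition of nuclear factor NF-kappa-B complex (Homo sapiens) (a lower number here means a stronger inhibitor, a higher number a weaker inhibitor), compound 1 gives 10000 nM, while compound 2 gives 20 nM. Among the measured compounds shown here, the single step between them, a 500-fold lower number from compound 1 to compound 2 (2.70 log units; beyond the scatter), is the only comparison on hand, and it places compound 2 as the lowest of the two numbers, with compound 1 as its nearest neighbour at a much higher value. Compound 3, `CCOC(=O)c1cnc(-c2ccncc2)nc1NN1C(=O)C=C(C)C1=O`, has not yet been measured. It differs from compound 2 in one place: pyridin-4-yl in place of thiophen-2-yl on an aromatic carbon. The measured step from compound 1 to compound 2 shows that a flat aromatic ring at this position is worth a great deal compared with a short chain; compound 3 keeps an aromatic ring there, so most of that gain is expected to remain, with some uncertainty about the new ring. Expected is a modest step of a 3.0-fold higher number from compound 2 to compound 3 (0.48 log units; beyond the scatter). Compound 3 is therefore estimated at 60 nM, in a range from 12 nM to 400 nM.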

Compound 3, half-maximal inhibitory concentration: 6000 nM
For compound 3 the middle estimate is 100-fold (2.00 log units) below the measured one; measured number above the stated range.
By their numbers in this assay, from the lowest: compound 2; then compounds 3 and 1 (each within the scatter of the next).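

The change gives a 300-fold higher number from compound 2 to compound 3 (2.48 log units; beyond the scatter) in this assay, even though thiophen-2-yl and pyridin-4-yl each place a single aromatic ring with one hetero atom on the same carbon, so having an aromatic ring here does not by itself bring a low number. With a 1.7-fold lower number from compound 1 to compound 3 (0.22 log units; within the scatter), pyridin-4-yl cannot be told apart from ethyl at this position, and among the three compounds only thiophen-2-yl gives a low number. Nothing available explains why these two rings differ so sharply.

The compounds shown leave open whether the low number depends on the five-membered ring, on its sulfur, or on how it is attached. Phenyl, furan-2-yl, thiophen-3-yl and pyridin-3-yl on this carbon would each help to separate these possibilities.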